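Replacing the side chain of compound 2

A few compounds are considered here, and "the series" means these few. Any claim that something is new, unique, unknown or untested is made for them only; others in the source may bear on it.

Compound 1 `CCCCc1oc2ccccc2c1C(=O)c1ccc(OCC(=O)N[C@@H](C)c2ccccc2)cc1`: 17900 nM
Compound 2 `CCCCc1oc2ccccc2c1C(=O)c1ccc(OCC(=O)N[C@H](C)c2ccccc2)cc1`: 14100 nM

Among the compounds with values here, in a functional assay on MCF7 cells (Homo sapiens) for antiproliferative activity, read by MTT assay, with a stated time of 24 h (on this read-out higher numbers stand for weaker inhibition and lower numbers for stronger inhibition), compound 2 gives 14100 nM, within the scatter of the only other number. Compound 3 `CCCCNC(=O)CCCOc1ccc(C(=O)c2c(CCCC)oc3ccccc23)cc1` has 2-(butylcarbamoyl)ethyl in place of (1-phenylethyl)carbamoyl on a saturated chain carbon bound to an oxygen on an aromatic ring. Within the data shown here, the sole measured step, a 1.3-fold lower number from compound 1 to compound 2 (0.10 log units; within the scatter), reflects the fact that compounds 1 and 2 differ only in the configuration as drawn and leaves this group unchanged, so it gives no size for the new change. No step beyond the scatter is therefore expected in this assay. The expected step is a 1.1-fold higher number from compound 2 to compound 3 (0.03 log units; within the scatter). Compound 3 is estimated at 15000 nM, with an expected range of 6000 nM to 40000 nM.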

Compound 3, half-maximal inhibitory concentration: > 50000 nM
Compound 3: only a limit was reported; the forecaster's own chance of this, stated with the estimate: 15%; middle value at least 3.3-fold (0.52 log units) away from the limit.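

In this assay compound 3 gives > 50000 nM, which is a limit and not a number. Placing 2-(butylcarbamoyl)ethyl in place of (1-phenylethyl)carbamoyl gives an at least 3.5-fold higher number from compound 2 to compound 3 (0.54 log units; beyond the scatter) and an at least 2.7-fold higher number from compound 1 to compound 3 (0.44 log units; beyond the scatter), so this position does respond to a change of group. The earlier step could give no size for such a change, because of this: the fact that compounds 1 and 2 differ only in the configuration as drawn

With only a limit, the full size of the step stays unknown, and the compounds shown do not separate losing the aromatic ring from gaining the ethyl link. On these data alone, whether a benzyl amide or a carboxylic acid at this place would hold the activity of compound 2 also stays open.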